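The source may report more compounds than this note shows. Statements on the series, on what has been measured and on what is new or still open speak of the compounds shown alone.

Measured compounds:
- compound 1 `Oc1ccc(-c2cc(-c3cccc(Cl)c3)nc(-c3ccccn3)c2)cc1`: in a functional assay on HCT-15 cells (Homo sapiens) for cytotoxicity, read by CCK-8 assay and cell counting, with a stated time of 2 days (on this read-out higher numbers stand for weaker inhibition and lower numbers for stronger inhibition), compound 1 gives 28200 nM
- compound 2 `Oc1cccc(-c2cc(-c3cccc(Cl)c3)nc(-c3ccccn3)c2)c1`: in this assay compound 2 gives "not determined" (no result reported)
- compound 3 `Oc1ccc(-c2cc(-c3ccncc3)nc(-c3cccc(Cl)c3)c2)cc1`: in this assay compound 3 gives "not determined" (no result reported)

Going by the values given here, compound 1 stands as the only compound of the series with a number in this assay; compounds 2 and 3 contribute nothing to compare against, so no step between measured compounds can be drawn.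

Compound 4 `Oc1ccc(-c2cc(-c3ccc(Cl)cc3)nc(-c3ccccn3)c2)cc1` differs from compound 1 by 4-chlorophenyl in place of 3-chlorophenyl on an aromatic carbon. With no measured step of this kind in the series, the move of the chlorine on the same ring is expected to change little: the step is estimated to lie within the usual scatter, with no direction assigned. Compound 4 is therefore expected to give 25000 nM in this assay, within 8000 nM to 80000 nM, an estimated step of a 1.1-fold lower number from compound 1 to compound 4 (0.05 log units; within the scatter).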

Compound 4, half-maximal inhibitory concentration: 21300 nM
Compound 4: the middle estimate sits 1.2-fold (0.07 log units) above what was measured; low and high end bracket the measured number.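

Going by these compounds alone, exchanging 3-chlorophenyl for 4-chlorophenyl on the aromatic carbon next to the ring nitrogen gives the first readable step in this assay: a 1.3-fold lower number from compound 1 to compound 4 (0.12 log units; within the scatter). At this place, the two chlorine placements are therefore not told apart by this read-out. No supporting data offer an explanation for this result.

Still open, as far as these compounds go, is whether a different group at this place, such as an amine, a carboxylic acid or an unsubstituted phenyl, would give a step beyond the scatter. From the compounds shown here alone, the contributions of the 4-hydroxyphenyl and pyridin-2-yl groups also remain open.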